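Aryl Change on the Shared Core: Cytotoxicity Notes

The compounds below may be only part of what the source reports. "The series", "measured", "known", "first", "only" and "open" are said of these compounds alone.

Among the measured compounds shown here, compound 1 `C=CCn1c(=O)/c(=C\c2ccccc2Cl)[nH]c(=O)/c1=C\c1ccccc1OC` is the only member of this set with a number: in a functional assay on MOLT-4 cells (Homo sapiens) for cytotoxicity, read by CCK-8 assay, with a stated time of 72 h (on this read-out higher numbers stand for weaker inhibition and lower numbers for stronger inhibition), compound 1 gives 4400 nM. Compound 2 `C=CCn1c(=O)/c(=C\c2cccc(Br)c2)[nH]c(=O)/c1=C\c1cccc(Br)c1` is recorded in this assay as "not active" (no number reported). Compound 3 `COc1ccccc1/C=c1/[nH]c(=O)/c(=C\c2ccccc2OC)[nH]c1=O` has no result in this assay, entered as "not determined" (no result reported). So compound 1 stands alone as the reference point, with nothing to rank it against.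

Compound 4 `C=CCn1c(=O)/c(=C\c2cccc(C)c2)[nH]c(=O)/c1=C\c1ccccc1OC` has not yet been run. Relative to compound 1 the change is 3-methylphenyl in place of 2-chlorophenyl on a double-bonded chain carbon bound to an aromatic carbon. For the measured compounds named here, no step between measured compounds exists to calibrate this exchange, so its size is unsupported; a step within the scatter, or at most a modest weakening, is expected in this assay. Compound 4 is therefore estimated at 6000 nM, between 2000 nM and 20000 nM, an expected step of a 1.4-fold higher number from compound 1 to compound 4 (0.13 log units; within the scatter).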

Compound 4, half-maximal inhibitory concentration: 16000 nM
For compound 4 the middle estimate is 2.7-fold (0.43 log units) below the measured one; measured number inside the range.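

In this assay, among the compounds shown here, 3-methylphenyl in place of 2-chlorophenyl on a double-bonded chain carbon bound to an aromatic carbon gives a 3.6-fold higher number from compound 1 to compound 4 (0.56 log units; beyond the scatter), the first readable step. This place therefore responds to the aryl group it carries, and compound 4 still returns a number. Nothing measured here bears on the origin of this step.

The exchange swaps chlorine for methyl and also moves the substituent on the ring, and the two changes remain unseparated. From the compounds shown here alone, how an aryl group bearing an amine or a carboxylic acid would read at this place remains open.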